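The source may report more compounds than this note shows. Statements on the series, on what has been measured and on what is new or still open speak of the compounds shown alone.

In a functional assay on ASPC1 cells (Homo sapiens) for inhibition, read by MTT assay, with a stated time of 96 h (a higher number here means a weaker inhibitor of growth, a lower number a stronger inhibitor of growth), compound 1 `O=C(NCCCCCCSSCCCCCCNC(=O)c1cc(-c2ccncc2)n[nH]1)c1cc(-c2ccncc2)n[nH]1` gives 25300 nM and compound 2 `O=C(OCc1ccccc1)SCCCCCCNC(=O)c1cc(-c2ccncc2)n[nH]1` gives 32300 nM. These two values lie within the scatter of each other, so compound 2 stands level with compound 1. Compound 3 `CC(C)C(=O)SCCCCCCNC(=O)c1cc(-c2ccncc2)n[nH]1` has isopropyl in place of benzyloxy on a carbonyl carbon. Among the compounds with values here, no measured pair shows the effect of this change, so no shift beyond the scatter is expected in this assay. The expected step is a 1.3-fold lower number from compound 2 to compound 3 (0.11 log units; within the scatter). For compound 3, the estimated value is 25000 nM, with an expected range from 10000 nM to 60000 nM.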

Compound 3, concentration for 50% growth inhibition: 31700 nM
Compound 3: the middle estimate sits 1.3-fold (0.10 log units) below what was measured; the range from low to high includes it.
By their numbers in this assay, from the lowest: compounds 1, 3 and 2 (each within the scatter of the next).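

In this assay, replacing benzyloxy with isopropyl on a carbonyl carbon gives a 1.0-fold lower number from compound 2 to compound 3 (0.01 log units; within the scatter), the first step measured at this position. The aromatic ring of benzyloxy can therefore leave, along with most of the group's heavy atoms, without any shift beyond the scatter in this assay. No evidence shown bears on this result.

As far as these compounds go, whether an amine or a carboxylic acid on that carbonyl carbon would move the number beyond the scatter remains open. So does the effect of a free thiol in place of the whole acyl group.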